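Shortening the alkyl chain on the ring nitrogen

A few compounds are considered here, and "the series" means these few. Any claim that something is new, unique, unknown or untested is made for them only; others in the source may bear on it.

Measured in a functional assay for antagonist activity at corticotropin-releasing factor receptor 1 (Rattus norvegicus); a higher number here means a weaker inhibitor, a lower number a stronger inhibitor:
Compound 1 `CC[C@H](COC)n1c(=O)c(C)nc2c(-c3ccc(Cl)cc3Cl)ncnc21` gives 97 nM.
Compound 2 `CCCC(C1CC1)n1c(=O)c(C)nc2c(-c3ccc(Cl)cc3Cl)ccnc21` gives 4.3 nM.
Compound 3 `CCC(C1CC1)n1c(=O)c(C)nc2c(-c3cc(C#N)c(C)cc3Cl)ccnc21` gives 4.8 nM.

Compound 2 has the lowest number of the three in this assay, with compound 3 so close that the two lie within the scatter, while compound 1 sits far beyond it. Compound 4 `CC[C@@H](C1CC1)n1c(=O)c(C)nc2c(-c3ccc(Cl)cc3Cl)ccnc21` differs from compound 2 in one place: 1-cyclopropylpropyl in place of 1-cyclopropylbutyl on an aromatic nitrogen. Compound 3 already carries a 1-cyclopropylpropyl group and, in this assay, compound 3 gives 4.8 nM, a number indistinguishable from that of compound 2. The step from compound 2 to compound 4 is therefore expected to stay within the scatter, in no clear direction, a 1.1-fold lower number from compound 2 to compound 4 (0.03 log units; within the scatter). Compound 4 is expected to give about 4 nM in this assay, in a range from 1.5 nM to 12 nM.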

Compound 4, half-maximal inhibitory concentration: 7.4 nM
For compound 4 the middle estimate is 1.9-fold (0.27 log units) below the measured one, within the range that was stated.
By their numbers in this assay, from the lowest: compounds 2, 3 and 4 (each within the scatter of the next); then compound 1.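

For the compounds shown here, on the aromatic nitrogen, 1-cyclopropylpropyl in place of 1-cyclopropylbutyl gives the first one-place comparison at this position: in this assay the step is a 1.7-fold higher number from compound 2 to compound 4 (0.24 log units; within the scatter) for the shorter chain, so potency holds at this level with either group. The entering group also has a defined stereocentre, which the step cannot separate from chain length. Nothing measured here gives a cause for the step. The compounds shown leave open the opposite enantiomer of 1-cyclopropylpropyl. They also leave open how a shorter 1-cyclopropylethyl group or a longer 1-cyclopropylpentyl chain would behave on this nitrogen.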